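A few compounds are considered here, and "the series" means these few. Any claim that something is new, unique, unknown or untested is made for them only; others in the source may bear on it.

In a functional assay on NCI-H1975 cells (Homo sapiens) for antiproliferative activity, read by CCK-8 assay, with a stated time of 72 h (on this read-out higher numbers stand for weaker inhibition of growth and lower numbers for stronger inhibition of growth), compound 1 `CC[C@@H]1C(=O)N(C)c2cnc(-n3ccc4cc(C(N)=O)ccc43)nc2N1C1CCCC1` gives 3380 nM. Among the compounds with values here, compound 2 `CCCNC(=O)c1ccc2c(ccn2-c2ncc3c(n2)N(C2CCCC2)[C@H](CC)C(=O)N3C)c1`, with propyl in place of hydrogen on an amide-type nitrogen, gives 786 nM, the lower of the two numbers measured so far and therefore the stronger inhibition of growth. Compound 3 `CC[C@@H]1C(=O)N(C)c2cnc(-n3ccc4cc(C(=O)NCC(C)C)ccc43)nc2N1C1CCCC1` keeps the shared core and changes only that chain: methyl in place of hydrogen on a saturated chain carbon bound to two saturated chain carbons. Put simply, this is methyl in place of hydrogen on a saturated chain carbon bound to two saturated chain carbons, which turns propyl into isobutyl.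

Within the data shown here, only one measured step bears on this change: a 4.3-fold lower number from compound 1 to compound 2 (0.63 log units; beyond the scatter), which lies beyond the scatter and came from adding the whole propyl. A single added methyl is a smaller alteration to the same chain, so a smaller step is expected in this assay, probably within the scatter, with a slight lean towards a lower number. The expected step is a 1.2-fold lower number from compound 2 to compound 3 (0.08 log units; within the scatter). For compound 3 the estimated value is 650 nM, with an expected range from 270 nM to 1500 nM.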

Compound 3, concentration for 50% growth inhibition: "not active" (no number reported)
Nothing numeric was reported for compound 3; there is nothing to compare the estimate with.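

Within the data shown here, compound 3 is reported in this assay only as "not active", without a number, and no step from compound 2 to compound 3 can be read. Nothing measured here offers an explanation for this result. The compounds shown leave open how the isobutyl chain of compound 3 compares in number with the propyl chain of compound 2.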